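A few compounds are considered here, and "the series" means these few. Any claim that something is new, unique, unknown or untested is made for them only; others in the source may bear on it.

Compound 1 `CC(=O)c1ccc2[nH]c(-c3ccc(C(F)(F)F)cc3)nc2c1` was tested in an ADME assay on BHK-21 cells (Mesocricetus auratus) for cytotoxicity, read by MTT assay; on this read-out lower numbers stand for higher toxicity in this test and higher numbers for lower toxicity in this test. In this assay compound 1 gives > 100000 nM, which is a limit of the test rather than a number. Compound 2 `C/C(=N\NC(N)=O)c1ccc2[nH]c(-c3ccc(C(F)(F)F)cc3)nc2c1` carries a group of 7 heavy atoms (3 carbon, 3 nitrogen, 1 oxygen; no ring) in place of a group of 3 heavy atoms (2 carbon, 1 oxygen; no ring), on an aromatic carbon. In this assay compound 2 gives > 100000 nM, again a limit. The step between them is a step that the two limits leave unreadable from compound 1 to compound 2. Compound 3 `CC(=O)c1ccc2c(c1)nc(-c1ccccc1)n2C1CCCCC1` has a different core, and the difference between the two cores is not broken down here. In this assay, among the compounds with values here, compound 3 gives 100000 nM, the only plain number among the three. Compound 4 `C/C(=N\NC(N)=O)c1ccc2c(c1)nc(-c1ccccc1)n2C1CCCCC1` is compound 3 with the same change, (a group of 7 heavy atoms (3 carbon, 3 nitrogen, 1 oxygen; no ring) in place of a group of 3 heavy atoms (2 carbon, 1 oxygen; no ring), on an aromatic carbon). Given the limit of > 100000 nM in this assay, at which 2 of the 3 values shown sit, and the unreadable step that the two limits leave unreadable from compound 1 to compound 2, the expected step from compound 3 to compound 4 is no change at the digits printed from compound 3 to compound 4 (within the scatter). Compound 4 is therefore estimated at 100000 nM, between 50000 nM and 200000 nM.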

Compound 4, half-maximal cytotoxic concentration: > 100000 nM
Compound 4 was reported as a limit; the forecaster's own chance of this, stated with the estimate: 60%; the middle value lies on the limit itself.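

In this assay the change from acetyl to the new group gives a number no lower from compound 3 to compound 4 (the limit leaves the size open), so on the core of compound 3 it brought no sign of higher toxicity in this test. The same change on the core of compound 1 cannot be read, so the size of the change cannot be compared between the two cores, and nothing shows that it would be the same on both. Little more can be drawn from this set: the limit of > 100000 nM in this assay, at which 3 of the 4 values shown sit.

From the compounds shown here alone, it remains open whether another group on this aromatic carbon, such as an amine or a carboxylic acid, would give a lower number. Going by these compounds, with a plain number only for compound 3, how far apart the four compounds truly lie also remains open.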